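Methoxy to Nitro in a Series at Its Limit

The source may report more compounds than this note shows. Statements on the series, on what has been measured and on what is new or still open speak of the compounds shown alone.

Measured so far in a functional assay on ECa-109 cells (Homo sapiens) for cytotoxicity, read by MTT assay, with a stated time of 48 h; a lower number here means a stronger inhibitor, a higher number a weaker inhibitor:
Compound 1 `COc1cc(-n2c(-c3ccc(O)cc3)c[nH]c2=O)cc(OC)c1OC` gives > 50000 nM (a limit)
Compound 2 `COc1ccc(-c2c[nH]c(=O)n2-c2cc(OC)c(OC)c(OC)c2)cc1` gives > 50000 nM (a limit)
Compound 3 `COc1ccc(-c2c[nH]c(=O)n2-c2cc(OC)c(OC)c(OC)c2)cc1OC` gives > 50000 nM (a limit)

For the measured compounds named here, compound 3 has only a limit and no number, and the same holds for the other two: the series so far shows the limit of > 50000 nM in this assay, at which 3 of the 3 values shown sit, and nothing else. Compound 4 `COc1ccc(-c2c[nH]c(=O)n2-c2cc(OC)c(OC)c(OC)c2)cc1[N+](=O)[O-]` differs from compound 3 by one change nitro in place of methoxy on an aromatic carbon in which nitro takes the place of methoxy on an aromatic carbon, ortho to a methoxy group and meta to a large group.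

Going by the values given here, two measured steps bear on this change. One is a step that the two limits leave unreadable from compound 2 to compound 3 where methoxy took the place of hydrogen on an aromatic carbon. The other is a step that the two limits leave unreadable from compound 1 to compound 2 where methyl took the place of hydrogen on an oxygen on an aromatic ring. Neither has a readable size, so neither gives a measure for the new step. The expectation therefore rests on the limit of > 50000 nM in this assay, at which 3 of the 3 values shown sit, and favours a reading at or near that limit for compound 4. The expected step is an at least 1.4-fold lower number from compound 3 to compound 4 (0.15 log units; that floor lies within the scatter) and any real movement is expected toward a stronger inhibitor. Compound 4 is estimated at 35000 nM with an expected range from 3000 nM to 100000 nM in this assay once it is measured.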

Compound 4, half-maximal inhibitory concentration: > 50000 nM
Compound 4: a limit, no number (the forecaster's own chance of this, stated with the estimate: 60%); middle value at least 1.4-fold (0.15 log units) from the limit.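

Neither step to compound 4, from compound 3 or from compound 2, can be read in this assay, and the series stays at a single limit: the limit of > 50000 nM in this assay, at which 4 of the 4 values shown sit. The compounds shown leave open what actual number any of these four compounds would give, and whether any change to the shared core would bring a value away from that limit.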